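Varying the Aryl Group on the Ring Nitrogen

The source may hold more compounds than are shown below. What is called first, only, known or untested is meant among the compounds shown, and "the series" means these compounds.

Within the data shown here, compound 2 `COc1cc2c(Oc3ccc(NC(=O)c4nn(-c5cccc(F)c5)c(=O)cc4C)cc3F)ccnc2cc1OCCCN1CCCC1` gives 170 nM in a functional assay on A549 cells (Homo sapiens) for inhibition, read by MTT assay, with a stated time of 72 h (on this read-out lower numbers stand for stronger inhibition and higher numbers for weaker inhibition), the highest of the two numbers measured so far. Its nearest neighbour, compound 1 `COc1cc2c(Oc3ccc(NC(=O)c4nn(-c5ccccc5OC(F)(F)F)c(=O)cc4C)cc3F)ccnc2cc1OCCCN1CCCC1`, gives 140 nM in this assay, and the gap between the two lies within the scatter. Among the measured compounds shown here, the one step that bears on the present change, a 1.2-fold higher number from compound 1 to compound 2 (0.08 log units; within the scatter), exchanged the aryl group on the aromatic nitrogen and left the read-out essentially unchanged. Compound 3 `COc1ccc(-n2nc(C(=O)Nc3ccc(Oc4ccnc5cc(OCCCN6CCCC6)c(OC)cc45)c(F)c3)c(C)cc2=O)cc1` differs from compound 2 by 4-methoxyphenyl in place of 3-fluorophenyl on an aromatic nitrogen. Because a 1.2-fold higher number from compound 1 to compound 2 (0.08 log units; within the scatter) stayed within the scatter when the same position was altered, a further exchange of the aryl group is expected to produce no step beyond the scatter in either direction. Compound 3 is therefore estimated at 170 nM, with a range from 70 nM to 400 nM. That estimate corresponds to an expected no change at the digits printed from compound 2 to compound 3 (within the scatter).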

Compound 3, half-maximal inhibitory concentration: 2770 nM
Beside the measured number, compound 3's estimate is 16-fold (1.21 log units) below it, outside the stated range (above it).
By their numbers in this assay, from the lowest: compounds 1 and 2 (each within the scatter of the next); then compound 3.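

In this assay, the aryl group on the aromatic nitrogen proves not to be a freely exchangeable position: 4-methoxyphenyl gives a 16-fold higher number from compound 2 to compound 3 (1.21 log units; beyond the scatter) and, against the other aryl group, a 20-fold higher number from compound 1 to compound 3 (1.30 log units; beyond the scatter) as well. The 3-fluorophenyl and 2-(trifluoromethoxy)phenyl compounds remain within the scatter of each other, so the two large steps set compound 3 apart from both, and the earlier pair gave no sign of such sensitivity. Nothing measured here accounts for the loss.

The change from compound 2 to compound 3 alters both the substituent and where it sits on the phenyl ring, so the compounds shown do not separate these two. A 3-methoxyphenyl, 4-fluorophenyl or unsubstituted phenyl group on the same nitrogen would bear on that question.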